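Dienone series on MGC-803 cells: swapping the nitrophenyl terminus

The source may hold more compounds than are shown below. What is called first, only, known or untested is meant among the compounds shown, and "the series" means these compounds.

Measured compounds:
compound 1 `O=C(/C=C/c1ccc(Oc2ncnc3ccc(Cl)cc23)cc1)/C=C/c1cc([N+](=O)[O-])ccc1Cl` gives 86.7%
compound 2 `O=C(/C=C/c1cc([N+](=O)[O-])ccc1Cl)/C=C/c1ccccc1Oc1ncnc2ccc(Cl)cc12` gives 91.6%

In a functional assay on MGC-803 cells (Homo sapiens) for inhibition, read by MTT assay, with a stated time of 72 h, tested at 10 uM (a higher number here means more inhibition of growth at the concentration tested, a lower number less inhibition of growth), compound 1 stands lowest of the two numbers; its nearest neighbour, compound 2, lies a few points higher, a gap within the scatter, so the two compounds are not separated by this assay.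

Compound 3 `O=C(/C=C/c1ccc(Oc2ncnc3ccc(Cl)cc23)cc1)/C=C/c1cccc(Cl)c1Cl` is not yet measured. It differs from compound 1 by 2,3-dichlorophenyl in place of 2-chloro-5-nitrophenyl on a double-bonded chain carbon bound to a double-bonded chain carbon. Among the measured compounds shown here, no step between measured compounds covers this change; the two measured values only show that the shared core reaches strong growth inhibition at the tested concentration with the nitro-bearing terminus in two arrangements.

For compound 3 the expectation is a small downward step, possibly none beyond the scatter, giving an estimated a number 8.7 percentage points lower from compound 1 to compound 3 (within the scatter). The expected value for compound 3 is 78%, with a range from 58% to 92%.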

Compound 3, percent growth inhibition at one concentration: 68.5%
Beside the measured number, compound 3's estimate is 9.5 percentage points above it, and the stated range covers the measured number.
By their numbers in this assay, from the lowest: compound 3; then compounds 1 and 2 (each within the scatter of the next).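

In this assay, the group on a double-bonded chain carbon bound to a double-bonded chain carbon proves able to shift growth inhibition: 2,3-dichlorophenyl in place of 2-chloro-5-nitrophenyl gives a number 18.2 percentage points lower from compound 1 to compound 3 (beyond the scatter). The two earlier compounds kept the same terminal group and were not separated, whereas this step shows that strong inhibition at the tested concentration does not follow from the shared core alone. No measurement at hand explains the step.

The change removes the nitro group and alters the chlorine pattern in a single swap, so the compounds shown cannot assign the step to either part. Also open, on these data alone, is how the terminus of compound 1 would read with an amine or a carboxylic acid in place of the nitro group.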